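From hydroxy to chloro on compound 2

This account rests on a few compounds, and the source may have more. Where it says the series, first, only, none or still open, it means among the compounds named here.

Compound 1 (`COC(=O)N1N=C(c2ccc(OC)cc2)CC1c1cc(OC)c(OC)c(OC)c1`) gives 1710 nM 
Compound 2 (`COC(=O)N1N=C(c2cccc(O)c2)CC1c1cc(OC)c(OC)c(OC)c1`) gives 650 nM 
Compound 3 (`CCOC(=O)N1N=C(c2cccc(O)c2)CC1c1cc(OC)c(OC)c(OC)c1`) gives 1790 nM 

These numbers come from a functional assay on HepG2 cells (Homo sapiens) for antiproliferative activity, read by MTT assay, with a stated time of 48 h (a lower number here means a stronger inhibitor of growth, a higher number a weaker inhibitor of growth), and compound 2 has the lowest of the three, which makes it the strongest inhibitor of growth so far. The next structure is compound 4 (`COC(=O)N1N=C(c2cccc(Cl)c2)CC1c1cc(OC)c(OC)c(OC)c1`), in which 3-hydroxyphenyl becomes 3-chlorophenyl, that is, chloro in place of hydroxy on an aromatic carbon. Going by the values given here, no measured compound carries chloro, so the evidence is indirect. The closest guide is the swap of 4-methoxyphenyl for 3-hydroxyphenyl, which gave a 2.6-fold lower number from compound 1 to compound 2 (0.42 log units; beyond the scatter) and shows a modest change at this group. The other measured step, a 2.8-fold higher number from compound 2 to compound 3 (0.44 log units; beyond the scatter), concerns a different part of the molecule and says little here. Compound 4 also loses the hydroxy, so a modest rise of similar size is expected, and the expected change in this assay is a 2.0-fold higher number from compound 2 to compound 4 (0.30 log units; within the scatter) as a weakening. Compound 4 is estimated at 1300 nM with 500 nM to 3300 nM as the expected range.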

Compound 4, concentration for 50% growth inhibition: 1240 nM
Compound 4: the middle estimate sits 1.0-fold (0.02 log units) above what was measured, within the range that was stated.
By their numbers in this assay, from the lowest: compounds 2, 4, 1 and 3 (each within the scatter of the next, the first and the last beyond it).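

Chloro in place of hydroxy gives a 1.9-fold higher number from compound 2 to compound 4 (0.28 log units; within the scatter) in this assay even though the hydrogen-bond donor and acceptor of the hydroxy leave, so the data do not show that the hydroxy on this aromatic carbon is needed for the reading of compound 2. The 3-chlorophenyl group gives a 1.4-fold lower number from compound 1 to compound 4 (0.14 log units; within the scatter) when set against 4-methoxyphenyl, so compound 4 cannot be told apart from either of these neighbours, although the step of a 2.6-fold lower number from compound 1 to compound 2 (0.42 log units; beyond the scatter) between those two lies beyond the scatter. Nothing available explains why these groups read as they do.

As far as these compounds go, it remains open whether an amine or a carboxylic acid on this aromatic carbon would move the number beyond the scatter of compound 2. Also open, from the compounds shown here alone, is whether the longer chain of compound 3 would have the same effect with chloro in place of hydroxy.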